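The source may report more compounds than this note shows. Statements on the series, on what has been measured and on what is new or still open speak of the compounds shown alone.

Measured compounds:
- compound 1 `O=C(NCc1cccnc1)Nc1ccc(S(=O)(=O)N2C3CCC2COC3)cc1`: 8 mL/min/kg
- compound 2 `O=C(NCc1cccnc1)Nc1ccc(S(=O)(=O)N2CC3(COC3)C2)cc1`: 7 mL/min/kg
- compound 3 `CC1CNCCN(S(=O)(=O)c2ccc(NC(=O)NCc3cccnc3)cc2)C1`: 8 mL/min/kg

In an ADME assay on microsomes from liver (Homo sapiens) for pharmacokinetics, read by LC-MS, with a stated time of 60 min, tested at 1 uM (on this read-out lower numbers stand for slow clearance and higher numbers for fast clearance), compound 1 gives 8 mL/min/kg. This is level with compound 3 at the digits shown and within the scatter of compound 2.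

Compound 4 `O=C(NCc1cccnc1)Nc1ccc(S(=O)(=O)N[C@H]2CC[C@H](O)CC2)cc1` is still unmeasured. The change from compound 1 is a group of 8 heavy atoms (6 carbon, 1 nitrogen, 1 oxygen; one six-membered non-aromatic ring of carbon only) in place of a group of 8 heavy atoms (6 carbon, 1 nitrogen, 1 oxygen; one five-membered non-aromatic ring with 1 hetero atom, one six-membered non-aromatic ring with 2 hetero atoms), on a sulfonyl sulfur. The entering group is (4-hydroxycyclohexyl)amino, on a sulfonyl sulfur.

Going by the values given here, three measured steps bear on this, as each replaces the group at that same place: a 1.1-fold lower number from compound 1 to compound 2 (0.06 log units; within the scatter), no change at the digits printed from compound 1 to compound 3 (within the scatter) and a 1.1-fold higher number from compound 2 to compound 3 (0.06 log units; within the scatter). All three are small and within the scatter. Among the compounds with values here, none of the measured compounds carries the (4-hydroxycyclohexyl)amino group, so these steps are only indirect evidence and the range stays wide, more so on the upper side.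

The expected change in this assay is no change at the digits printed from compound 1 to compound 4 (within the scatter), with no step beyond the scatter in either direction. For compound 4 the estimated value is 8 mL/min/kg, with an expected range of 5 mL/min/kg to 15 mL/min/kg.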

Compound 4, clearance: 2 mL/min/kg
Estimate against measurement, compound 4: 4.0-fold (0.60 log units) above; the measured number lies below the stated range.
By their numbers in this assay, from the lowest: compound 4; then compounds 2, 1 and 3 (each within the scatter of the next).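

Going by these compounds alone, at the sulfonyl sulfur, the read-out in this assay is not flat across all groups, as the earlier compounds alone suggested: (4-hydroxycyclohexyl)amino gives a 4.0-fold lower number from compound 1 to compound 4 (0.60 log units; beyond the scatter), with a 4.0-fold lower number from compound 3 to compound 4 (0.60 log units; beyond the scatter) and a 3.5-fold lower number from compound 2 to compound 4 (0.54 log units; beyond the scatter), which places compound 4 lowest of the four. The entering group brings a ring of carbon only, hydrogen-bond donors and defined stereocentres together, so this series cannot assign the step to any one of these features. No measurement is at hand that explains the lower clearance number.

Still open, as far as these compounds go, is whether the hydroxyl itself is needed, a question that plain cyclohexylamino or (4-methoxycyclohexyl)amino would address at this place. Also open, from the compounds shown here alone, is whether the other stereoisomer of (4-hydroxycyclohexyl)amino would give a similar number.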